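A few compounds are considered here, and "the series" means these few. Any claim that something is new, unique, unknown or untested is made for them only; others in the source may bear on it.

Measured compounds in a functional assay on HCT-116 cells (Homo sapiens) for antiproliferative activity, read by MTT assay, with a stated time of 72 h; on this read-out higher numbers stand for weaker inhibition and lower numbers for stronger inhibition:
compound 1 `CN(C(=O)CCc1ccccc1)c1ccc2[nH]c(-c3n[nH]c4ccccc34)cc2n1` gives 11200 nM;
compound 2 `COc1ccc(C(=O)N(C)c2ccc3[nH]c(-c4n[nH]c5ccccc45)cc3n2)cc1` gives 29500 nM;
compound 3 `Cc1ccc(S(=O)(=O)N(C)c2ccc3[nH]c(-c4n[nH]c5ccccc45)cc3n2)cc1` gives 13300 nM.

Compound 1 has the lowest of the three numbers; the step to compound 3 is a 1.2-fold higher number from compound 1 to compound 3 (0.07 log units; within the scatter) and the step to compound 2 is a 2.6-fold higher number from compound 1 to compound 2 (0.42 log units; beyond the scatter). Compound 4 `CN(c1ccc2[nH]c(-c3n[nH]c4ccccc34)cc2n1)S(=O)(=O)c1ccc(Cl)cc1` differs from compound 1 in one place: (4-chlorophenyl)sulfonyl in place of phenethylcarbonyl on a nitrogen on an aromatic ring. The step that bears on it most is a 1.2-fold higher number from compound 1 to compound 3 (0.07 log units; within the scatter), since that change also puts a sulfonyl bearing a substituted phenyl on the same nitrogen; the step of a 2.2-fold lower number from compound 2 to compound 3 (0.35 log units; beyond the scatter) adds little to that. Within the data shown here, no step with a chloro group in this position is available. Compound 4 is therefore expected near compound 1, with the step of a 1.1-fold higher number from compound 1 to compound 4 (0.03 log units; within the scatter) in this assay. Estimated value for compound 4: 12000 nM, range 6000 nM to 26000 nM.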

Compound 4, half-maximal inhibitory concentration: 5980 nM
Compound 4: middle estimate off by 2.0-fold (0.30 log units), on the high side, and the stated range ends above it.
By their numbers in this assay, from the lowest: compounds 4, 1 and 3 (each within the scatter of the next, the first and the last beyond it); then compound 2.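

In this assay, the aromatic substituent on the sulfonyl group changes the read-out: chloro in place of methyl on an aromatic carbon gives a 2.2-fold lower number from compound 3 to compound 4 (0.35 log units; beyond the scatter). Among these compounds, exchanging phenethylcarbonyl for (4-chlorophenyl)sulfonyl gives a 1.9-fold lower number from compound 1 to compound 4 (0.27 log units; within the scatter), which stays within the scatter, whereas exchanging (4-methoxyphenyl)carbonyl for it gives a 4.9-fold lower number from compound 2 to compound 4 (0.69 log units; beyond the scatter), the largest step so far. No available measurement accounts for these steps.

The compounds shown leave open whether an amine or a carboxylic acid on that aromatic carbon would follow the chloro step. They also leave open how a (4-chlorophenyl)carbonyl group on the same nitrogen would compare.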